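Thioether side chain variation on the shared core

The compounds below may be only part of what the source reports. "The series", "measured", "known", "first", "only" and "open" are said of these compounds alone.

The three measured compounds share one core and differ only in the group on the sulfur. In a functional assay on HT cells (Homo sapiens) for antiproliferative activity, read by fluorescence, with a stated time of 72 h (on this read-out higher numbers stand for weaker inhibition of growth and lower numbers for stronger inhibition of growth), compound 1 `CC(C)c1n[nH]c2c(NCc3ccc(-c4ccccn4)cc3)nc(SCC(N)=O)nc12` gives 192 nM. Compound 2 `CCC(O)CSc1nc(NCc2ccc(-c3ccccn3)cc2)c2[nH]nc(C(C)C)c2n1` gives 273 nM, and compound 3 `CC(C)c1n[nH]c2c(NCc3ccc(-c4ccccn4)cc3)nc(SCCCN(C)C)nc12` gives 105 nM, the lowest number of the three, though only one of its gaps is beyond the scatter: a 1.8-fold lower number from compound 1 to compound 3 (0.26 log units; within the scatter), while a 2.6-fold lower number from compound 2 to compound 3 (0.41 log units; beyond the scatter). Compound 4 `CC(C)c1n[nH]c2c(NCc3ccc(-c4ccccn4)cc3)nc(SC3CCCCC3O)nc12` carries 2-hydroxycyclohexyl in place of 3-(dimethylamino)propyl on a sulfur. Both earlier steps concern the same sulfur substituent, and the hydroxyl-bearing chain of compound 2 gave the highest number of the set. Because a 2.6-fold lower number from compound 2 to compound 3 (0.41 log units; beyond the scatter), a modest rise is expected for compound 4: a 2.1-fold higher number from compound 3 to compound 4 (0.32 log units; beyond the scatter). Compound 4 is estimated at 220 nM, in a range from 90 nM to 550 nM.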

Compound 4, concentration for 50% growth inhibition: 636 nM
The estimate for compound 4 lay 2.9-fold (0.46 log units) below the measured number; measured number above the stated range.
By their numbers in this assay, from the lowest: compounds 3, 1 and 2 (each within the scatter of the next, the first and the last beyond it); then compound 4.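

In this assay, among the compounds shown here, the steps of a 6.1-fold higher number from compound 3 to compound 4 (0.78 log units; beyond the scatter) and a 2.3-fold higher number from compound 2 to compound 4 (0.37 log units; beyond the scatter) and a 3.3-fold higher number from compound 1 to compound 4 (0.52 log units; beyond the scatter) leave 2-hydroxycyclohexyl on the sulfur with the highest number so far, each step beyond the scatter. A hydroxyl on the group therefore does not fix the number at this position, since the cyclic 2-hydroxycyclohexyl and the open-chain 2-hydroxybutyl stand apart. No measurement shown here accounts for this rise.

The compounds shown leave open whether the rise goes with the ring or with its hydroxyl. Plain cyclohexyl or 2-aminocyclohexyl on the sulfur would separate the two.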